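This account rests on a few compounds, and the source may have more. Where it says the series, first, only, none or still open, it means among the compounds named here.

Measured so far:
- compound 1, `N#Cc1c(N)nc(SCc2cccc(C(N)=O)c2)c(C#N)c1-c1ccc(OCC2CC2)cc1`, giving 1%
- compound 2, `N#Cc1c(N)nc(SCC(=O)NO)c(C#N)c1-c1ccc(OCC2CC2)cc1`, giving 31%

Going by the values given here, in an assay on CHO cells for displacement of a labelled ligand from adenosine receptor A3 (Homo sapiens), read by scintillation counting, with a stated time of 120 min, tested at 1 uM (on this read-out lower numbers stand for less inhibition and higher numbers for more inhibition at the one concentration tested (going by the name of the read-out)), compound 2 holds the higher of the two numbers, and the only step known, a number 30 percentage points higher from compound 1 to compound 2 (beyond the scatter), lies beyond the scatter. Compound 3, `N#Cc1c(N)nc(SCc2csc(N)n2)c(C#N)c1-c1ccc(OCC2CC2)cc1`, differs from compound 2 by 2-amino-1,3-thiazol-4-yl in place of hydroxycarbamoyl on a saturated chain carbon bound to a sulfur. Among the compounds with values here, no measured step covers this exact exchange; the one step available shows that swapping a group on that sulfur-bound carbon can shift the number modestly, and the aromatic group of compound 1 gave the lower value. Compound 3 is therefore expected to fall, by about a number 19 percentage points lower from compound 2 to compound 3 (beyond the scatter), to an estimated 12%, within a range of 0% to 40%.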

Compound 3, a percentage reported as inhibition, at one concentration (the size of the read-out at that concentration, not a potency): 1%
Compound 3: middle estimate off by 11 percentage points, on the high side; low and high end bracket the measured number.
By their numbers in this assay, from the lowest: compounds 1 and 3 (each within the scatter of the next); then compound 2.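

In this assay, 2-amino-1,3-thiazol-4-yl does not hold the level seen with hydroxycarbamoyl on this saturated chain carbon bound to a sulfur, giving a number 30 percentage points lower from compound 2 to compound 3 (beyond the scatter). Two different ring groups at this place now read alike, with no change at the digits printed from compound 1 to compound 3 (within the scatter), so among these three compounds only the non-ring hydroxycarbamoyl of compound 2 stands apart. Nothing measured here explains this difference.

As far as these compounds go, it remains open whether the higher number needs the whole hydroxycarbamoyl group. A carboxylic acid on the same carbon, or a longer chain carrying hydroxycarbamoyl, would help to answer that.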